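Shortening the chain on the ring nitrogen: clearance notes

This account rests on a few compounds, and the source may have more. Where it says the series, first, only, none or still open, it means among the compounds named here.

Measured compounds:
compound 1 `COc1cc(N(CC(C)C)c2cccc(C(F)(F)F)c2)cnc1C(=O)[C@H]1C[C@@H]1C(=O)O` — in an ADME assay on cells (Hepatocyte, Homo sapiens) for metabolic stability, read by LC-MS, with a stated time of 60 min, tested at 1 uM (on this read-out higher numbers stand for fast clearance and lower numbers for slow clearance), compound 1 gives 2.9 uL/min
compound 3 `CCCN(c1cccc(C(F)(F)F)c1)c1cnc(C(=O)[C@H]2C[C@@H]2C(=O)O)c(OC)c1` — in this assay compound 3 gives 7.2 uL/min
compound 2 `COc1cc(N(CC(C)(C)O)c2cccc(C(F)(F)F)c2)cnc1C(=O)[C@H]1C[C@@H]1C(=O)O` — in this assay compound 2 gives "not determined" (no result reported)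

Within the data shown here, compound 3 holds the higher of the two numbers, with compound 1 the only neighbour, a 2.5-fold higher number from compound 1 to compound 3 (0.39 log units; beyond the scatter), a change that is hydrogen in place of methyl on a saturated chain carbon bound to two saturated chain carbons.

Compound 4 `CCN(c1cccc(C(F)(F)F)c1)c1cnc(C(=O)[C@H]2C[C@@H]2C(=O)O)c(OC)c1` differs from compound 3 by hydrogen in place of methyl on a saturated chain carbon, two bonds along the chain from a nitrogen on an aromatic ring

Among the measured compounds shown here, only the step from compound 1 to compound 3 bears on this, and it was modest. A change of similar kind is therefore expected to give a small rise at most, a 1.3-fold higher number from compound 3 to compound 4 (0.10 log units; within the scatter), with the scatter easily covering no change. Compound 4 is estimated at 9 uL/min, in the range 4.5 uL/min to 18 uL/min.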

Compound 4, intrinsic clearance in a liver preparation (reported as CLH), per the amount of preparation that the assay uses: 3.1 uL/min
Estimate against measurement, compound 4: 2.9-fold (0.46 log units) above, and the stated range ends above it.
By their numbers in this assay, from the lowest: compounds 1 and 4 (each within the scatter of the next); then compound 3.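

In this assay propyl to ethyl gives a 2.3-fold lower number from compound 3 to compound 4 (0.37 log units; beyond the scatter) and this runs opposite to a 2.5-fold higher number from compound 1 to compound 3 (0.39 log units; beyond the scatter) so the number does not rise steadily as the chain shortens, with compound 4 going against that pattern. Methyl in place of isopropyl on the chain carbon bound to the nitrogen gives a 1.1-fold higher number from compound 1 to compound 4 (0.03 log units; within the scatter) and leaves compound 3 alone at the high end. No evidence on the reason for this reversal is available.

The steps involving compound 2 cannot be read, as it has no number. As far as these compounds go, what a butyl chain or an amine on the chain would give remains open.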